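This account rests on a few compounds, and the source may have more. Where it says the series, first, only, none or still open, it means among the compounds named here.

Measured in an ADME assay on microsomes (Homo sapiens) for metabolic stability; on this read-out higher numbers stand for fast clearance and lower numbers for slow clearance:

- Compound 1 `CNC(=O)[C@@H]1CCCN1S(=O)(=O)c1ccc(Cl)c(COc2cccc3c(-n4ccnc4)cc(C)nc23)c1Cl`: 33.3 mL/min/kg
- Compound 2 `CNC(=O)[C@@H]1CCCN1S(=O)(=O)c1ccc(Cl)c(COc2cccc3c(-c4cncn4C)cc(C)nc23)c1Cl`: 33.3 mL/min/kg

Compound 2 stands level with compound 1 at the digits shown. Compound 3 `CNC(=O)[C@@H]1CCCN1S(=O)(=O)c1ccc(Cl)c(COc2cccc3c(-c4nccn4C)cc(C)nc23)c1Cl` has the same atoms as compound 2, joined differently: 1-methyl-1H-imidazol-2-yl in place of 1-methyl-1H-imidazol-5-yl on an aromatic carbon. In compound 3, 1-methyl-1H-imidazol-2-yl replaces 1-methyl-1H-imidazol-5-yl on an aromatic carbon, opposite the ring nitrogen.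

Within the data shown here, only one measured step bears on this change: no change at the digits printed from compound 1 to compound 2 (within the scatter), which lies within the scatter. It exchanged 1H-imidazol-1-yl for 1-methyl-1H-imidazol-5-yl on that same aromatic carbon. Among the measured compounds shown here, a single step is thin evidence, and no measured compound yet carries 1-methyl-1H-imidazol-2-yl. A shift beyond the scatter in this assay is therefore not expected, and no direction is favoured. The expected result is a 1.1-fold lower number from compound 2 to compound 3 (0.05 log units; within the scatter). For compound 3 the estimate is 30 mL/min/kg, with an expected range of 16 mL/min/kg to 48 mL/min/kg.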

Compound 3, clearance: 117 mL/min/kg
Compound 3: the middle estimate sits 3.9-fold (0.59 log units) below what was measured; the measured number lies above the stated range.
By their numbers in this assay, from the lowest: compounds 1 and 2 (each within the scatter of the next); then compound 3.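

In this assay, the position opposite the ring nitrogen turns out to be sensitive to how the imidazole is joined: with the atoms unchanged, 1-methyl-1H-imidazol-2-yl in place of 1-methyl-1H-imidazol-5-yl gives a 3.5-fold higher number from compound 2 to compound 3 (0.55 log units; beyond the scatter). The same group in place of 1H-imidazol-1-yl gives a 3.5-fold higher number from compound 1 to compound 3 (0.55 log units; beyond the scatter), so a tolerance suggested by the matching numbers of compound 1 and compound 2 does not extend to every imidazole at this position. Nothing available here explains this rise in clearance.

From the compounds shown here alone, it remains open whether a 1H-imidazol-2-yl group without the methyl would give a number like that of compound 3 or like that of compound 2. Going by these compounds, how a pyridin-3-yl ring or a simple amine would behave at this position also remains open.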